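Hydroxyl for methyl on the pendant phenyl of compound 2

This account rests on a few compounds, and the source may have more. Where it says the series, first, only, none or still open, it means among the compounds named here.

The series rests on a shared core, seen in compound 1 `Cc1ccccc1-c1ccccc1OC(C)C1=NCCN1` and compound 2 `Cc1cccc(-c2ccccc2OC(C)C2=NCCN2)c1`. In an assay on CHO cells for displacement of a labelled ligand from Alpha-2B adrenergic receptor (Homo sapiens) (on this read-out higher numbers stand for weaker inhibition and lower numbers for stronger inhibition), compound 1 gives 832 nM, and compound 2 gives 537 nM. For the measured compounds named here, the only measured step, a 1.5-fold lower number from compound 1 to compound 2 (0.19 log units; within the scatter), moves the methyl on the pendant phenyl and stays within the scatter. Among the two numbers, compound 2 shows the lower one, yet its step to compound 1 does not go beyond the scatter, so no order can be claimed between them.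

Compound 3 `CC(Oc1ccccc1-c1ccc(O)cc1)C1=NCCN1` is not yet measured. It differs from compound 2 in one place: 4-hydroxyphenyl in place of 3-methylphenyl on an aromatic carbon. Going by the values given here, no measured step exchanges a methyl for a hydroxyl on this phenyl, and the one step on record, from compound 1 to compound 2, is within the scatter, so it gives no direction for this change. A modest shift of either sign, or none beyond the scatter, is therefore expected, as a 1.3-fold higher number from compound 2 to compound 3 (0.12 log units; within the scatter) in this assay. Compound 3 is estimated at 700 nM, with a range from 200 nM to 2500 nM.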

Compound 3, inhibition constant: 813 nM
Beside the measured number, compound 3's estimate is 1.2-fold (0.06 log units) below it; low and high end bracket the measured number.
By their numbers in this assay, from the lowest: compounds 2, 3 and 1 (each within the scatter of the next).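

In this assay, for the compounds shown here, the step of a 1.5-fold higher number from compound 2 to compound 3 (0.18 log units; within the scatter) is the first to put a hydroxyl in place of a methyl on the pendant phenyl, and the step of a 1.0-fold lower number from compound 1 to compound 3 (0.01 log units; within the scatter) sets the same group against the other methylphenyl. The ring on this aromatic carbon can therefore be 4-hydroxyphenyl, with 1 hydrogen-bond donor and 1 hydrogen-bond acceptor, or either methylphenyl, with 0 of each, and all three compounds still lie within the scatter of one another on this read-out. Compound 3 differs from both methyl compounds in the kind of group and in where it sits on the ring, and neither difference shows beyond the scatter here; no evidence is available to account for how close these numbers lie.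

What the compounds shown leave open is whether the hydroxyl and the methyl would separate if they stood at the same place, as in a comparison of 3-hydroxyphenyl with 3-methylphenyl. As far as these compounds go, it also remains open whether a different group on this phenyl, such as an amine, a carboxylic acid or a methoxy, would give a step beyond the scatter.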